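Trimethoxyphenyl in place of methoxyphenyl on the aromatic carbon

The source may hold more compounds than are shown below. What is called first, only, known or untested is meant among the compounds shown, and "the series" means these compounds.

Going by the values given here, in a functional assay on HT-29 cells (Homo sapiens) for antiproliferative activity, read by MTT assay, with a stated time of 48 h (on this read-out lower numbers stand for stronger inhibition and higher numbers for weaker inhibition), compound 2 `COc1ccc(-c2nn(-c3ccccc3)cc2C(=O)/C=C\Nc2cc(OC)c(OC)c(OC)c2)cc1` gives 14600 nM, the highest of the two numbers so far; compound 1 `COc1ccc(-c2nn(-c3ccccc3)cc2C(=O)/C=C\Nc2ccc(O)cc2)cc1` gives 2460 nM in this assay. Among the compounds with values here, the one measured step, a 5.9-fold higher number from compound 1 to compound 2 (0.77 log units; beyond the scatter), concerns the group on the amine nitrogen. Compound 3 `COc1cc(N/C=C\C(=O)c2cn(-c3ccccc3)nc2-c2cc(OC)c(OC)c(OC)c2)cc(OC)c1OC` differs from compound 2 at another place: 3,4,5-trimethoxyphenyl in place of 4-methoxyphenyl on an aromatic carbon. Within the data shown here, no measured step touches this position, so that step does not bear on it directly. The expected step is none beyond the scatter, a 1.0-fold higher number from compound 2 to compound 3 (0.01 log units; within the scatter). Compound 3 is therefore estimated at 15000 nM, within 5000 nM to 45000 nM.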

Compound 3, half-maximal inhibitory concentration: 8400 nM
For compound 3 the middle estimate is 1.8-fold (0.25 log units) above the measured one; low and high end bracket the measured number.
By their numbers in this assay, from the lowest: compound 1; then compounds 3 and 2 (each within the scatter of the next).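

In this assay, 3,4,5-trimethoxyphenyl in place of 4-methoxyphenyl on the aromatic carbon gives a 1.7-fold lower number from compound 2 to compound 3 (0.24 log units; within the scatter), so this first reading at the position shows no separable difference, even with 12 heavy atoms entering for 8. The reading holds only with 3,4,5-trimethoxyphenyl on the amine nitrogen. No supporting data bear on why the two compounds read alike.

On these data alone, whether the same exchange reads alike with the 4-hydroxyphenyl of compound 1 on the amine nitrogen remains open. So does the reading of a carboxylic acid or an amine on this aromatic carbon.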